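A few compounds are considered here, and "the series" means these few. Any claim that something is new, unique, unknown or untested is made for them only; others in the source may bear on it.

Two compounds of one series have been run in a functional assay on MGC-803 cells (Homo sapiens) for antiproliferative activity, read by CCK-8 assay, with a stated time of 72 h, tested at 8 uM; on this read-out lower numbers stand for a weaker effect and higher numbers for a stronger effect at the one concentration tested. Compound 1 `Nc1ccccc1NC(=O)c1ccc(CSC(=S)N2CCN(Cc3cccnc3)CC2)cc1` carries a (pyridin-3-yl)methyl group on the ring nitrogen, and in this assay compound 1 gives 64.6%. Compound 2 `Nc1ccccc1NC(=O)c1ccc(CSC(=S)N2CCN(c3ccncc3)CC2)cc1` carries pyridin-4-yl at the same place, and in this assay compound 2 gives 87.1%. Within the data shown here, the one step that joins them, a number 22.5 percentage points higher from compound 1 to compound 2 (beyond the scatter), is the only comparison in hand, and on it compound 2 stands highest of the two numbers.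

Compound 3 `Nc1ccccc1NC(=O)c1ccc(CSC(=S)N2CCN(Cc3ccccc3)CC2)cc1` has not yet been measured. It differs from compound 2 in one place: benzyl in place of pyridin-4-yl on an amine nitrogen in a ring. Among the measured compounds shown here, no measured step carries a benzyl group, so the step from compound 1 to compound 2 is the only one that bears on it, and it only shows that exchanging a methylene-linked pyridine for a directly attached one raised the read-out by a modest amount. Since compound 3 returns to a methylene-linked aromatic ring, a value nearer compound 1 is expected, with the step of a number 19.1 percentage points lower from compound 2 to compound 3 (beyond the scatter) estimated as a drop from compound 2. Compound 3 is therefore expected to give about 68% in this assay, with a range from 50% to 88%.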

Compound 3, a percentage reported as inhibition, at one concentration (the size of the read-out at that concentration, not a potency): 19.7%
Estimate against measurement, compound 3: 48.3 percentage points above; the measured number lies below the stated range.
By their numbers in this assay, from the lowest: compound 3; then compound 1; then compound 2.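

In this assay, benzyl in place of pyridin-4-yl on the amine nitrogen in the ring gives a number 67.4 percentage points lower from compound 2 to compound 3 (beyond the scatter), and phenyl in place of pyridin-3-yl on the saturated chain carbon gives a number 44.9 percentage points lower from compound 1 to compound 3 (beyond the scatter), which leaves compound 3 the weakest of the three at the one concentration tested. The second step is the more telling one: the methylene link stays and only the aromatic ring changes, from one with a hetero atom to one of carbon only, so at this position the read-out depends on the ring itself and not only on how it is attached, which the earlier pair of pyridines could not show. Nothing at hand explains why the nitrogen-containing rings give the higher numbers.

The compounds shown leave open how a phenyl group bound straight to the ring nitrogen would compare with pyridin-4-yl, which would separate the effect of the link from that of the ring. From the compounds shown here alone, it also remains open how (pyridin-4-yl)methyl or pyridin-3-yl bound straight to that nitrogen would read, and so whether the place of the ring nitrogen matters apart from the methylene link.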